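Chalcone amides: cytotoxicity on Vero cells

The compounds below may be only part of what the source reports. "The series", "measured", "known", "first", "only" and "open" are said of these compounds alone.

Measured so far:
compound 1 `CC(C)Cc1ccc(C(=O)/C=C/c2ccc(C(=O)O)cc2)cc1` — < 10 ug/mL
compound 2 `CCOc1ccc(C(=O)/C=C/c2ccc(C(=O)Nc3cccc(-c4cc(C(=O)OC)no4)c3)cc2)cc1` — > 40 ug/mL
compound 3 `CCOC(=O)c1nnn(-c2cccc(NC(=O)c3ccc(/C=C/C(=O)c4ccc(Cl)cc4)cc3)c2)c1C` — "not determined" (no result reported)

In an ADME assay on Vero cells (Chlorocebus sabaeus) for cytotoxicity, read by MTT assay, with a stated time of 72 h (on this read-out higher numbers stand for lower toxicity in this test and lower numbers for higher toxicity in this test), compound 1 gives < 10 ug/mL, which is a limit of the test and not a number. It sits at the limit of < 10 ug/mL in this assay, at which 1 of the 3 values shown sits. Compound 2 gives > 40 ug/mL in this assay, again a limit rather than a number. It sits at the limit of > 40 ug/mL in this assay, at which 1 of the 3 values shown sits. Compound 3 has "not determined" (no result reported) in this assay, so no result is reported for it.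

Compound 4 `COC(=O)c1cc(-c2cccc(NC(=O)c3ccc(/C=C/C(=O)c4cccc(OC)c4)cc3)c2)on1` has not yet been measured. It differs from compound 2 by 3-methoxyphenyl in place of 4-ethoxyphenyl on a carbonyl carbon. Within the data shown here, no step between measured compounds is known, so the expectation rests on the change alone: a step within the usual scatter, with no direction, is expected, a step that the limit leaves unreadable from compound 2 to compound 4. Compound 4 is expected to give about 45 ug/mL in this assay, between 20 ug/mL and 90 ug/mL, most likely again as a limit.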

Compound 4, half-maximal cytotoxic concentration: > 100 ug/mL
Compound 4: a limit, no number; the forecaster's own chance of this, stated with the estimate: 70%; middle value at least 2.2-fold (0.34 log units) away from the limit.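

Among these compounds, the results for compound 2 and compound 4 are both limits of the test, and no step between them can be read. The compounds shown leave open how large the effect of 3-methoxyphenyl in place of 4-ethoxyphenyl on a carbonyl carbon is, or in which direction it runs.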